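Moving the nitro group on the sulfonyl ring of a benzyl analogue

The compounds below may be only part of what the source reports. "The series", "measured", "known", "first", "only" and "open" are said of these compounds alone.

Measured compounds:
- compound 1, `COc1ccc(Cc2nnc(NC(=O)/C(C#N)=C/c3ccccc3OS(=O)(=O)c3ccc([N+](=O)[O-])cc3)s2)cc1`: 70%
- compound 2, `COc1ccc(Cc2nnc(NC(=O)/C(C#N)=C/c3ccccc3OS(=O)(=O)c3ccccc3[N+](=O)[O-])s2)cc1`: 68%
- compound 3, `N#C/C(=C\c1ccccc1OS(=O)(=O)c1ccc([N+](=O)[O-])cc1)C(=O)Nc1nnc(Cc2ccccc2)s1`: 57%

All three were tested in a functional assay on RS4-11 cells (Homo sapiens) for inhibition, read by CCK-8 assay, with a stated time of 48 h, tested at 20 uM; a higher number here means more inhibition of growth at the concentration tested, a lower number less inhibition of growth. Compound 1 and compound 2 share one core and differ only in the group on the sulfonyl sulfur: 2-nitrophenyl in place of 4-nitrophenyl on a sulfonyl sulfur. That change gave a number 2 percentage points lower from compound 1 to compound 2 (within the scatter), so the two compounds cannot be told apart here.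

Compound 3 has a different core from compound 1, and the difference is small: hydrogen in place of methoxy on an aromatic carbon. This change gave a number 13 percentage points lower from compound 1 to compound 3 (beyond the scatter), a modest loss. Among the three measured compounds, compound 3 gives the lowest number, and its distance from both others lies beyond the usual scatter.

Compound 4, `N#C/C(=C\c1ccccc1OS(=O)(=O)c1ccccc1[N+](=O)[O-])C(=O)Nc1nnc(Cc2ccccc2)s1`, has not yet been measured. It stands to compound 3 exactly as compound 2 stands to compound 1: 2-nitrophenyl in place of 4-nitrophenyl on a sulfonyl sulfur. The place of the change is the same in both pairs, a sulfonyl sulfur whose other neighbour is an oxygen on an aromatic ring, so this is the same change made on the other core.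

Among the compounds with values here, the one earlier example of this change, compound 1 to compound 2, gave a number 2 percentage points lower from compound 1 to compound 2 (within the scatter). On that basis the step is expected to be small again, a number 2 percentage points lower from compound 3 to compound 4 (within the scatter), with compound 3 as the starting point. Compound 4 is therefore estimated to give 55% in this assay, expected to fall between 43% and 67%. The estimate rests on a single earlier pair, so it carries real uncertainty.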

Compound 4, percent growth inhibition at one concentration: 71%
Beside the measured number, compound 4's estimate is 16 percentage points below it; the whole stated range lies below it.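

The swap of 4-nitrophenyl for 2-nitrophenyl on the sulfonyl sulfur did not carry over unchanged from one core to the other. In this assay it gave a number 14 percentage points higher from compound 3 to compound 4 (beyond the scatter), and this does not match the earlier example of the same change: the same change on two cores in this assay, a number 2 percentage points lower (within the scatter) from compound 1 to compound 2 and a number 14 percentage points higher (beyond the scatter) from compound 3 to compound 4, 16 percentage points apart, beyond the scatter of two such steps

Read the other way, hydrogen in place of methoxy on an aromatic carbon gave a number 3 percentage points higher from compound 2 to compound 4 (within the scatter), so among these four compounds the size of each step depends on what stands at the other place: the same change on two cores in this assay, a number 13 percentage points lower (beyond the scatter) from compound 1 to compound 3 and a number 3 percentage points higher (within the scatter) from compound 2 to compound 4, 16 percentage points apart, beyond the scatter of two such steps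

Within the data shown here, this shows that a step taken from one core was a poor guide to the same step on the other core here, but with only two pairs it does not explain the mismatch or show what the change would do on any further core.

The compounds shown leave open whether the nitro group is needed at all, as a sulfonyl ring carrying an amine or a carboxylic acid in its place would test. Going by these compounds, it is also open whether the same mismatch would appear with an ethoxy group or a chlorine in place of the methoxy.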